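The compounds below may be only part of what the source reports. "The series", "measured", "known", "first", "only" and "open" are said of these compounds alone.

Compound 1, `CC[C@@H]1CN(c2scnc2-c2nc3ccccc3[nH]2)CCN1C(=O)Cn1cnc2cccnc21`: 851 nM
Compound 2, `Cc1nc(-c2nc3ccccc3[nH]2)c(N2CCN(C(=O)Cn3cnc4cccnc43)[C@H](C)C2)s1`: 1060 nM

In an assay on blood for inhibition of C-X-C chemokine receptor type 3 (Homo sapiens), with a stated time of 30 min (on this read-out higher numbers stand for weaker inhibition and lower numbers for stronger inhibition), compound 2 gives 1060 nM, the higher of the two numbers recorded. Compound 1 gives 851 nM; the gap between the two lies within the scatter of repeated measurements, so on this read-out the pair cannot be told apart. Compound 3, `C[C@@H]1CN(c2sc(Br)nc2-c2nc3ccccc3[nH]2)CCN1C(=O)Cn1cnc2cccnc21`, differs from compound 2 in one place: bromo in place of methyl on an aromatic carbon. Among the compounds with values here, no measured pair shows this exchange, so nothing in the data sets its size. Compound 1 and compound 2 differ in several places yet sit within the scatter of each other, which hints that the shared core tolerates some variation at this ring without large movement. The step from compound 2 to compound 3 is therefore expected to be small, a 1.2-fold lower number from compound 2 to compound 3 (0.07 log units; within the scatter), without a firm direction. Compound 3 is estimated at 900 nM, with a range from 350 nM to 2500 nM.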

Compound 3, half-maximal inhibitory concentration: 526 nM
Estimate against measurement, compound 3: 1.7-fold (0.23 log units) above; the measured number falls inside the stated range.
By their numbers in this assay, from the lowest: compounds 3, 1 and 2 (each within the scatter of the next).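

In this assay, within the data shown here, the step of a 2.0-fold lower number from compound 2 to compound 3 (0.30 log units; within the scatter) is the only direct reading so far at this position, on an aromatic carbon of a five-membered aromatic ring with 1 nitrogen and 1 sulfur. It shows that bromo in place of methyl, one heavy atom for another, does not carry the number beyond the scatter, so this pair cannot be told apart and the step sets no firm direction. Nothing among the data shown accounts for the size of this step.

With only methyl and bromo compared directly, the compounds shown leave open how this position would respond to a larger or very different group, such as an amine, a carboxylic acid or a longer chain. They also leave open whether any such group would move the number beyond the scatter.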